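Chain-terminus variation on a shared core

The source may hold more compounds than are shown below. What is called first, only, known or untested is meant among the compounds shown, and "the series" means these compounds.

Compound 1 `CCCCCCCCN1CCC(c2c[nH]c3ccc(NC(=O)c4ccc(F)cc4)cc23)CC1` — > 1000 nM
Compound 2 `CN(C)CCCN1CCC(c2c[nH]c3ccc(NC(=O)c4ccc(F)cc4)cc23)CC1` — > 1000 nM

In an assay on CHO-K1 cells for displacement of a labelled ligand from 5-hydroxytryptamine receptor 1B (Homo sapiens), read by scintillation counting (a lower number here means a stronger inhibitor, a higher number a weaker inhibitor), compound 1 reaches only the assay limit, > 1000 nM. Compound 2 likewise gives only a limit in this assay, > 1000 nM. The two differ by dimethylamino in place of pentyl on a saturated chain carbon, three bonds along the chain from an amine nitrogen in a ring, and the step that the two limits leave unreadable from compound 1 to compound 2 cannot be sized, because of the limit of > 1000 nM in this assay, at which 2 of the 2 values shown sit.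

Compound 3 `O=C(O)CCCCCCCCCN1CCC(c2c[nH]c3ccc(NC(=O)c4ccc(F)cc4)cc23)CC1` carries the change (6-carboxyhexyl in place of dimethylamino on a saturated chain carbon, three bonds along the chain from an amine nitrogen in a ring). For the measured compounds named here, no measured step bears on it in a readable way: the only comparison is unreadable, and both values so far are limits. No shift beyond the scatter can be read from the data, so a limit is the likelier outcome again. Compound 3 is therefore estimated at 1500 nM, within 300 nM to 8000 nM in this assay. The step this implies is expected to be a step that the limit leaves unreadable from compound 2 to compound 3.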

Compound 3, inhibition constant: > 1000 nM
Compound 3: only a limit was reported (the forecaster's own chance of this, stated with the estimate: 70%); the middle value lies beyond the limit too.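

For the compounds shown here, compound 1, compound 2 and compound 3 all stop at a limit in this assay, so no step among them can be read: (the limit of > 1000 nM in this assay, at which 3 of the 3 values shown sit). Still open, going by these compounds, is whether any chain terminus on the shared core gives a measurable value in this assay.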